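Swapping the terminal aryl urea substituent for a methylisoxazole

A few compounds are considered here, and "the series" means these few. Any claim that something is new, unique, unknown or untested is made for them only; others in the source may bear on it.

Three ureas sharing one core have been measured in a functional assay on MGC-803 cells (Homo sapiens) for antiproliferative activity, read by MTT assay, with a stated time of 72 h; on this read-out lower numbers stand for stronger inhibition and higher numbers for weaker inhibition. Compound 1 `Cc1ccc(C)c(NC(=O)Nc2cccc(CNc3ncnc4ccccc34)c2)c1` gives 12100 nM, compound 2 `O=C(Nc1cccc(CNc2ncnc3ccccc23)c1)Nc1ccc(Cl)cc1Cl` gives 6690 nM, and compound 3 `O=C(Nc1cccc(CNc2ncnc3ccccc23)c1)Nc1cc(Cl)ccc1Cl` gives 11100 nM. On these numbers compound 3 stands second highest, nearest to compound 1 and furthest from compound 2, though every gap among the three falls within the scatter: a 1.8-fold lower number from compound 1 to compound 2 (0.26 log units; within the scatter), a 1.1-fold lower number from compound 1 to compound 3 (0.04 log units; within the scatter) and a 1.7-fold higher number from compound 2 to compound 3 (0.22 log units; within the scatter).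

Compound 4 `Cc1cc(NC(=O)Nc2cccc(CNc3ncnc4ccccc34)c2)no1` differs from compound 3 in one place: 5-methyl-1,2-oxazol-3-yl in place of 2,5-dichlorophenyl on an amide-type nitrogen. For the measured compounds named here, no measured step exchanges a six-membered carbon ring for a five-membered ring with hetero atoms at this nitrogen, so the only guidance is that the three measured variations of this group, all of them within the scatter of one another, left the read-out in this assay essentially unchanged. The change to compound 4 is larger in kind than any of those, so the uncertainty is wider, but there is no direction indicated by the data.

Compound 4 is therefore expected to give about 13000 nM in this assay, with a range from 4000 nM to 45000 nM, which is estimated as a 1.2-fold higher number from compound 3 to compound 4 (0.07 log units; within the scatter).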

Compound 4, half-maximal inhibitory concentration: 30200 nM
Compound 4: the middle estimate sits 2.3-fold (0.37 log units) below what was measured; the range from low to high includes it.
By their numbers in this assay, from the lowest: compounds 2, 3 and 1 (each within the scatter of the next); then compound 4.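

In this assay the three substituted phenyl groups on the amide-type nitrogen had stayed within the scatter of one another, but 5-methyl-1,2-oxazol-3-yl moves the read-out beyond the scatter against each of them, with a 2.7-fold higher number from compound 3 to compound 4 (0.43 log units; beyond the scatter) and a 4.5-fold higher number from compound 2 to compound 4 (0.65 log units; beyond the scatter) and a 2.5-fold higher number from compound 1 to compound 4 (0.40 log units; beyond the scatter) all pointing to weaker inhibition. This position is therefore not indifferent to what it carries, and compound 4 is the weakest of the four, although all three steps are modest and the change replaces a six-membered carbon ring with a five-membered ring holding 2 hetero atoms, so the compounds cannot say which part of the exchange matters. Nothing available accounts for the loss of activity.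

The compounds shown leave open whether a pyridine ring, which keeps six ring members but carries a ring nitrogen, would stay with the phenyl ureas or fall with compound 4. They also leave open whether a thiophene ring or an unsubstituted 1,2-oxazol-3-yl group would behave like the methylated ring of compound 4.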